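The compounds below may be only part of what the source reports. "The series", "measured", "known", "first", "only" and "open" are said of these compounds alone.

In an ADME assay on L132 cells (Homo sapiens) for cytotoxicity, read by MTT assay, with a stated time of 48 h (on this read-out higher numbers stand for weaker inhibition and lower numbers for stronger inhibition), compound 3 (`C/C(=C\CC/C(C)=C/CC[C@@H]1[C@@]2(C)CCC(=O)C(C)(C)[C@H]2CC[C@@]1(C)O)CC/C=C(\C)C(=O)OCc1cn(-c2cccc(C)c2)nn1`) gives > 150000 nM, which is a limit of the assay and not a number. Compound 1 (`C/C(=C\CC/C(C)=C/CC[C@@H]1[C@@]2(C)CCC(=O)C(C)(C)[C@H]2CC[C@@]1(C)O)CC/C=C(\C)C(=O)OCc1cn(-c2ccc([N+](=O)[O-])cc2)nn1`) gives > 150000 nM, also a limit. Compound 2 (`C/C(=C\CC/C(C)=C/CC[C@@H]1[C@@]2(C)CCC(=O)C(C)(C)[C@H]2CC[C@@]1(C)O)CC/C=C(\C)C(=O)OCc1cn(-c2ccccc2C(F)(F)F)nn1`) gives > 150000 nM, again a limit. Compound 3 therefore shares its place with the other two, and the overall picture is the limit of > 150000 nM in this assay, at which 3 of the 3 values shown sit.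

Compound 4 (`C/C(=C\CC/C(C)=C/CC[C@@H]1[C@@]2(C)CCC(=O)C(C)(C)[C@H]2CC[C@@]1(C)O)CC/C=C(\C)C(=O)OCc1cn(-c2cccc(Cl)c2)nn1`) has 3-chlorophenyl where compound 3 has 3-methylphenyl, with chloro in place of methyl on an aromatic carbon, meta to a large group: chloro in place of methyl on an aromatic carbon.

The measured steps that bear on this change the same aromatic group: a step that the two limits leave unreadable from compound 1 to compound 3, a step that the two limits leave unreadable from compound 2 to compound 3 and a step that the two limits leave unreadable from compound 1 to compound 2. None of them gives a size or a direction. The expectation therefore rests on compound 3, whose limit is > 150000 nM, and no step beyond the usual scatter is expected. The expected change is a step that the limit leaves unreadable from compound 3 to compound 4. For compound 4 the estimated value is 160000 nM, with an expected range from 90000 nM to 300000 nM.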

Compound 4, half-maximal inhibitory concentration: 94200 nM
Compound 4: middle estimate off by 1.7-fold (0.23 log units), on the high side; the measured number falls inside the stated range.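

Among the compounds shown, compound 4 alone gives a number in this assay, and the others stay at a limit of the assay: the limit of > 150000 nM in this assay, at which 3 of the 4 values shown sit. With chloro in place of methyl on the aromatic ring, meta to a large group, there is an at least 1.5-fold lower number from compound 3 to compound 4 (0.20 log units; that floor lies within the scatter), so this change now has a readable direction, although its printed floor does not exceed ordinary scatter. Changing the whole group on the aromatic nitrogen gives the same kind of result, with an at least 1.5-fold lower number from compound 2 to compound 4 (0.20 log units; that floor lies within the scatter) and an at least 1.5-fold lower number from compound 1 to compound 4 (0.20 log units; that floor lies within the scatter).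

As far as these compounds go, the steps among compound 1, compound 2 and compound 3 cannot be read, and the true sizes of the three new steps remain unknown, since each gives only a floor. From the compounds shown here alone, it also remains open whether a bromo, a methoxy or an amino group in place of this chloro would give a number rather than a limit.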